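Dichlorophenoxy propanamides: cytotoxicity on hamster ovary cells

The compounds below may be only part of what the source reports. "The series", "measured", "known", "first", "only" and "open" are said of these compounds alone.

Measured in an ADME assay on CHO cells (Cricetulus griseus) for cytotoxicity, read by LDH release; on this read-out higher numbers stand for weaker inhibition and lower numbers for stronger inhibition:
Compound 1 `CC(Oc1ccc(Cl)cc1Cl)C(=O)NCc1ccccc1`: compound 1 gives 95000 nM.
Compound 2 `CC(Oc1ccc(Cl)cc1Cl)C(=O)NCc1ccccc1F`: compound 2 gives 47000 nM.
Compound 3 `Cc1ccccc1CNC(=O)C(C)Oc1ccc(Cl)cc1Cl`: compound 3 gives only a limit of the assay, > 100000 nM, not a number.

Compound 1 holds the highest of the two numbers; its nearest neighbour is compound 2, with a 2.0-fold lower number from compound 1 to compound 2 (0.31 log units; beyond the scatter). Compound 3 sits at the limit of > 100000 nM in this assay, at which 1 of the 3 values shown sits.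

Compound 4 `COc1ccc(CNC(=O)C(C)Oc2ccc(Cl)cc2Cl)cc1` differs from compound 1 by methoxy in place of hydrogen on an aromatic carbon. For the measured compounds named here, the steps that bear on it are the two other substitutions on the same aromatic ring: fluoro gave a 2.0-fold lower number from compound 1 to compound 2 (0.31 log units; beyond the scatter), while methyl gave an at least 1.0-fold higher number from compound 1 to compound 3 (0.02 log units; that floor lies within the scatter) and, from compound 2, an at least 2.1-fold higher number from compound 2 to compound 3 (0.32 log units; beyond the scatter). Small groups on this ring have thus moved the number by no more than a modest amount in either direction, with the methyl case tending toward weaker inhibition. For methoxy no step beyond the scatter is expected, if anything a slight rise, and a limit is a real possibility.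

Compound 4 is expected to give about 110000 nM, within 55000 nM to 220000 nM. The expected step is a 1.2-fold higher number from compound 1 to compound 4 (0.06 log units; within the scatter).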

Compound 4, half-maximal inhibitory concentration: 71000 nM
The estimate for compound 4 lay 1.5-fold (0.19 log units) above the measured number; the range from low to high includes it.
By their numbers in this assay, from the lowest: compounds 2, 4 and 1 (each within the scatter of the next, the first and the last beyond it). At a limit, above all of these: compound 3.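

In this assay, methoxy in place of hydrogen on an aromatic carbon, para to a large group, gives a 1.3-fold lower number from compound 1 to compound 4 (0.13 log units; within the scatter) and so stays within the scatter. The earlier steps shown here covered only fluoro and methyl, and this adds a group of 2 heavy atoms with 1 hydrogen-bond acceptor at a place on the ring where no step can be told from the scatter. Compound 4 also gives a number rather than a limit of the assay, but nothing shown explains why this change leaves the read-out so close to that of compound 1.

Going by these compounds, it remains open whether an amine, a carboxylic acid or a longer chain such as butoxy at this place on the ring would give a step beyond the scatter. The compounds shown also leave open what changes to the amide hydrogen or to the two chloro groups of the shared core would do.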